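The compounds below may be only part of what the source reports. "The series", "measured", "known", "first", "only" and "open" are said of these compounds alone.

Of the compounds shown here, three from this series have been measured in an assay on isolated protein for binding affinity to leukotriene B4 receptor 1 (Homo sapiens), tested at 1 uM; on this read-out lower numbers stand for less inhibition and higher numbers for more inhibition at the one concentration tested (going by the name of the read-out). Compound 1 `CC(=O)c1cc(CO)c(OCCCCCCC#N)cc1O` gives 8%, compound 3 `CCc1cc(C(C)=O)c(O)cc1OCCCCCCC(C)(C)C#N` gives 30%, and compound 2 `C=CCc1cc(C(C)=O)c(O)cc1OCCCCCCCC#N` gives 52%. Compound 2 thus stands highest of the three, and both gaps below it, to compound 3 and to compound 1, lie beyond the usual scatter of this assay. All three carry a nitrile at the far end of the chain attached through the aromatic oxygen, so none of them tells what happens when that end is changed.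

Compound 4 `C=CCc1cc(C(C)=O)c(O)cc1OCCCCCC(C)=O` is the next candidate. Its structure differs from compound 2 in one place: acetyl in place of 2-cyanoethyl on a saturated chain carbon, five bonds along the chain from an oxygen on an aromatic ring. For the measured compounds named here, no measured pair shows the effect of this change, so the expected size of the step in this assay is uncertain; a moderate drop is expected, though a result within the scatter cannot be ruled out. The step from compound 2 to compound 4 is expected to be a number 14 percentage points lower from compound 2 to compound 4 (beyond the scatter). Compound 4 is estimated to give 38%, between 15% and 62%.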

Compound 4, a percentage reported as inhibition, at one concentration (the size of the read-out at that concentration, not a potency): 58%
Estimate against measurement, compound 4: 20 percentage points below; the measured number falls inside the stated range.
By their numbers in this assay, from the lowest: compound 1; then compound 3; then compounds 2 and 4 (each within the scatter of the next).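

In this assay, putting acetyl in place of 2-cyanoethyl on a saturated chain carbon, five bonds along the chain from an oxygen on an aromatic ring, gives a number 6 percentage points higher from compound 2 to compound 4 (within the scatter), so the two numbers cannot be told apart. For the compounds shown here, the earlier compounds all ended in a nitrile, and this pair is the first to show that, at least on this shared core, the read-out holds up with a ketone carbonyl at that chain end instead. Nothing available explains why the two groups give such similar numbers.

As far as these compounds go, it remains open whether a carboxylic acid, an amine or an amide at the same chain end would also keep the number. It is equally open whether acetyl on a longer chain would do so, or whether the same swap would behave alike on the other cores shown here.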